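A Ring Fluorine Added to the Phenethyl Arm of Compound 2

A few compounds are considered here, and "the series" means these few. Any claim that something is new, unique, unknown or untested is made for them only; others in the source may bear on it.

Measured so far in an assay on CHO cells for displacement of a labelled ligand from 5-hydroxytryptamine receptor 1B (Homo sapiens); a higher number here means a weaker inhibitor, a lower number a stronger inhibitor:
Compound 1, `FC1(Cc2ccccc2C(F)(F)F)CCN(CCCc2c[nH]c3ccc(-n4cnnc4)cc23)CC1`: 14 nM
Compound 2, `FC1(CCc2ccccc2)CCN(CCCc2c[nH]c3ccc(-n4cnnc4)cc23)CC1`: 49 nM

Going by the values given here, of the two compounds measured, compound 2 gives the higher number in this assay, and the only neighbour is compound 1, from which the move a 3.5-fold higher number from compound 1 to compound 2 (0.54 log units; beyond the scatter) separates it. Among the compounds with values here, that step exchanges one whole aryl arm for another and is the sole measured step in the set.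

Compound 3, `Fc1ccccc1CCC1(F)CCN(CCCc2c[nH]c3ccc(-n4cnnc4)cc23)CC1`, is the next compound. It differs from compound 2 by fluoro in place of hydrogen on an aromatic carbon, a single atom added to the aromatic ring of the phenethyl group while everything else stays as it is. Within the data shown here, no measured pair shows this particular change, so the step from compound 1 to compound 2 bears on it only indirectly, in that it marks how far this arm has moved the number so far. The change to compound 3 is expected to be small, with an estimated step of a 1.4-fold lower number from compound 2 to compound 3 (0.15 log units; within the scatter), not clearly beyond the scatter in either direction. Compound 3 is therefore expected to give about 35 nM, within 14 nM to 100 nM.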

Compound 3, half-maximal inhibitory concentration: 16 nM
Compound 3: middle estimate off by 2.2-fold (0.34 log units), on the high side, and the stated range covers the measured number.
By their numbers in this assay, from the lowest: compounds 1 and 3 (each within the scatter of the next); then compound 2.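

In this assay, one fluoro on the aromatic ring of the phenethyl arm, ortho to a large group, is enough to shift the number, with a 3.1-fold lower number from compound 2 to compound 3 (0.49 log units; beyond the scatter), so a single added atom at this carbon counts for a step of much the same order as the exchange of the whole arm, a 3.5-fold higher number from compound 1 to compound 2 (0.54 log units; beyond the scatter). The new arm also brings the series back level with the earlier arm, with a 1.1-fold higher number from compound 1 to compound 3 (0.06 log units; within the scatter), which leaves the two arms that carry a ring substituent together within the scatter and compound 2, whose ring carries none, apart from both. No measurement at hand bears on why this hydrogen-to-fluoro change moves the number as it does.

Going by these compounds, whether a chloro, methyl or methoxy group on this same aromatic carbon would do what fluoro does remains open, and so does what a trifluoromethyl group there would do on the phenethyl arm. On these data alone, it is also open whether the step belongs to this particular ring carbon or would recur with fluoro on another carbon of the ring.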